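The source may hold more compounds than are shown below. What is called first, only, known or untested is meant among the compounds shown, and "the series" means these compounds.

Measured so far:
compound 1, `O=C(Nc1cc(-c2ccccc2)nn1-c1ccccc1)c1cccc(C(F)(F)F)c1` – 228 nM
compound 2, `O=C(Nc1cc(-c2ccccc2)nn1-c1ccccc1Br)c1ccc([N+](=O)[O-])cc1` – 61 nM

In a functional assay on cells for positive allosteric modulation of metabotropic glutamate receptor 5 (Rattus norvegicus), read by calcium flux (on this read-out lower numbers stand for an effect already at smaller amounts and higher numbers for an effect only at larger amounts of compound), compound 1 gives the higher of the two numbers, 228 nM. Compound 2 gives 61 nM, and the gap between the two lies beyond the usual scatter, so compound 1 is the weaker of the pair. Compound 3, `O=C(CC1CCCC1)Nc1cc(-c2ccccc2)nn1-c1ccccc1`, has not yet been measured. It differs from compound 1 in one place: cyclopentylmethyl in place of 3-(trifluoromethyl)phenyl on a carbonyl carbon. For the measured compounds named here, no measured pair shows a change of this kind, so the expectation rests on the two compounds alone, both of which carry a six-membered aromatic ring of carbon only on the carbonyl carbon, where compound 3 carries a five-membered non-aromatic ring instead. The step is expected to move toward a higher number, a 3.9-fold higher number from compound 1 to compound 3 (0.60 log units; beyond the scatter), beyond the scatter. Compound 3 is therefore estimated at 900 nM in this assay, within a range from 200 nM to 4000 nM.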

Compound 3, half-maximal effective concentration: 350 nM
Beside the measured number, compound 3's estimate is 2.6-fold (0.41 log units) above it; the range from low to high includes it.
By their numbers in this assay, from the lowest: compound 2; then compounds 1 and 3 (each within the scatter of the next).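

On the carbonyl carbon, this assay records a 1.5-fold higher number from compound 1 to compound 3 (0.19 log units; within the scatter) when cyclopentylmethyl replaces 3-(trifluoromethyl)phenyl. For this pair, then, a six-membered aromatic ring of carbon only is not needed at this position to stay within the scatter: a five-membered non-aromatic ring of carbon only, in a group with fewer heavy atoms, serves as well on this read-out. No measurement at hand bears on why the two compounds lie so close. What the compounds shown leave open is whether this holds for other groups on the carbonyl carbon, such as a longer straight carbon chain, an amine or a carboxylic acid. They also leave open whether the same replacement would give a similar step on another substitution of the shared core.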